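Nitro Replacing Phenyl on the Aryloxy Ketone Tail

The compounds below may be only part of what the source reports. "The series", "measured", "known", "first", "only" and "open" are said of these compounds alone.

Compound 1 `CC(C)[C@H](NC(=O)COc1cccc2ccccc12)C(=O)N[C@@H](CC(=O)O)C(=O)COc1ccc(-c2ccccc2)cc1` gives 87900 nM in a functional assay on Jurkat cells (Homo sapiens) (on this read-out higher numbers stand for weaker inhibition and lower numbers for stronger inhibition), the highest of the two numbers shown there, with compound 3 `CC(C)[C@H](NC(=O)COc1cccc2ccccc12)C(=O)N[C@@H](CC(=O)O)C(=O)COc1ccc(OC(F)(F)F)cc1` standing nearest at 29100 nM. Compound 2 `CC(C)[C@H](NC(=O)COc1cccc2ccccc12)C(=O)N[C@@H](CC(=O)O)C(=O)COc1ccc(C(N)=O)cc1` reaches only the limit (the limit of > 100000 nM in this assay, at which 1 of the 3 values shown sits), reported as > 100000 nM. Compound 4 `CC(C)[C@H](NC(=O)COc1cccc2ccccc12)C(=O)N[C@@H](CC(=O)O)C(=O)COc1ccc([N+](=O)[O-])cc1` differs from compound 1 by nitro in place of phenyl on an aromatic carbon. For the measured compounds named here, two measured steps touch the same aromatic carbon: a 3.0-fold lower number from compound 1 to compound 3 (0.48 log units; beyond the scatter), and an at least 1.1-fold higher number from compound 1 to compound 2 (0.05 log units; that floor lies within the scatter). One swap helps modestly, the other does not, and nitro matches neither precedent closely. For compound 4 a step of a 1.5-fold lower number from compound 1 to compound 4 (0.17 log units; within the scatter) is therefore expected in this assay, lying between those two outcomes. Compound 4 is estimated at 60000 nM, with a range from 20000 nM to 150000 nM.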

Compound 4, half-maximal inhibitory concentration: > 100000 nM
Compound 4: a limit, no number; the forecaster's own chance of this, stated with the estimate: 35%; middle value at least 1.6-fold (0.22 log units) away from the limit.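

From the compounds shown here alone, compound 4 gives no number in this assay, and with compound 2 it is the second compound at this aromatic carbon to reach a limit: the limit of > 100000 nM in this assay, at which 2 of the 4 values shown sit. Against compound 1 the result reads only as an at least 1.1-fold higher number from compound 1 to compound 4 (0.05 log units; that floor lies within the scatter), so the size of the nitro-for-phenyl change stays unknown, while compound 3 is set apart by an at least 3.4-fold higher number from compound 3 to compound 4 (0.53 log units; beyond the scatter). The step between compound 2 and compound 4 cannot be read, since both values are limits.

Going by these compounds, whether methoxy, chlorine or trifluoromethyl at this place would match compound 3 remains open. So do the actual values of compound 2 and compound 4.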